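Diaryl amides: benzoyl in place of acetyl on the anilide

The source may hold more compounds than are shown below. What is called first, only, known or untested is meant among the compounds shown, and "the series" means these compounds.

Compound 1, `Cc1ccc(NC(=O)Nc2cc(F)cc(C(F)(F)F)c2)cc1NC(=O)c1ccccc1`: > 30000 nM
Compound 2, `CC(=O)Nc1cc(NC(=O)c2cc(C(F)(F)F)cc(C(F)(F)F)c2)ccc1C`: > 30000 nM

In a functional assay on A375P cells (Homo sapiens) for antiproliferative activity (a lower number here means a stronger inhibitor, a higher number a weaker inhibitor), compound 1 reaches only the assay limit, > 30000 nM. Compound 2 likewise gives only a limit, > 30000 nM. Among the compounds with values here, compound 2 therefore stands at the limit of > 30000 nM in this assay, at which 2 of the 2 values shown sit, and no step between measured compounds exists. Compound 3, `Cc1ccc(NC(=O)c2cc(C(F)(F)F)cc(C(F)(F)F)c2)cc1NC(=O)c1ccccc1`, carries phenyl in place of methyl on a carbonyl carbon. Within the data shown here, no measured pair shows this change, so no step beyond the scatter is expected in this assay in either direction. Compound 3 is expected to give about 25000 nM, estimated between 5000 nM and 60000 nM. That estimate would mean the step of an at least 1.2-fold lower number from compound 2 to compound 3 (0.07 log units; that floor lies within the scatter), and a limit again is the likeliest outcome.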

Compound 3, half-maximal inhibitory concentration: > 30000 nM
Compound 3: a limit, no number; the forecaster's own chance of this, stated with the estimate: 70%; at least 1.2-fold (0.07 log units) between middle value and limit.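

In this assay, within the data shown here, compound 3 gives > 30000 nM, a limit and not a number, as compound 2 also does, so no step between compound 2 and compound 3 can be read. The compounds shown leave open whether phenyl in place of methyl on a carbonyl carbon changes activity in this assay at all.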